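The source may hold more compounds than are shown below. What is called first, only, known or untested is meant among the compounds shown, and "the series" means these compounds.

Of the compounds shown here, three have so far been measured in an assay on H4 cells for inhibition of Fatty-acid amide hydrolase 1 (Homo sapiens); on this read-out lower numbers stand for stronger inhibition and higher numbers for weaker inhibition. Compound 1 `CCOC(=O)CC(C)CCCCCn1c(C)nc(-c2ccccc2)c1-c1ccccc1` gives 130 nM, compound 2 `Cc1nc(-c2ccccc2)c(-c2ccccc2)n1CCCCCCNC(=O)Oc1ccccc1` gives 5.3 nM, and compound 3 `CCOC(=O)CCCCCCn1c(C)nc(-c2ccc(F)cc2)c1-c1ccc(F)cc1` gives 64 nM. Compound 3 stands second highest of the three numbers: its nearest neighbour is compound 1, whose number is higher, and the furthest is compound 2, whose number is lower. Compound 1 and compound 3 differ in more than one place, so only their two values are set side by side here. The change from compound 3 to compound 4 `Cc1nc(-c2ccc(F)cc2)c(-c2ccc(F)cc2)n1CCCCCCNC(=O)Oc1ccccc1F` is ((2-fluorophenoxy)carbonyl)amino in place of ethoxycarbonyl on a saturated chain carbon, six bonds along the chain from an aromatic nitrogen. Going by the values given here, one measured step bears on it, a 25-fold lower number from compound 1 to compound 2 (1.39 log units; beyond the scatter), which exchanges an ethoxycarbonyl-bearing chain for a phenoxycarbonylamino-bearing one on the shared core. Among the compounds with values here, the present change carries the same exchange, with a fluorine added on the phenoxy ring, for which no measured step exists. A large step toward a lower number in this assay is therefore expected, a 21-fold lower number from compound 3 to compound 4 (1.33 log units; beyond the scatter). The value expected for compound 4 in this assay is 3 nM, with a range from 1 nM to 10 nM.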

Compound 4, half-maximal inhibitory concentration: 10 nM
Beside the measured number, compound 4's estimate is 3.3-fold (0.52 log units) below it, and the stated range covers the measured number.
By their numbers in this assay, from the lowest: compounds 2 and 4 (each within the scatter of the next); then compound 3; then compound 1.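

In this assay, ((2-fluorophenoxy)carbonyl)amino in place of ethoxycarbonyl on a saturated chain carbon, six bonds along the chain from an aromatic nitrogen, gives a 6.4-fold lower number from compound 3 to compound 4 (0.81 log units; beyond the scatter). The earlier step, a 25-fold lower number from compound 1 to compound 2 (1.39 log units; beyond the scatter), was a related exchange on a different chain and core, so the direction now holds in both listed steps, although the groups exchanged are not the same. Nothing available explains this step.

The compounds shown do not separate the fluorine on the phenoxy ring from the fluorines on the shared core, as no pair differs in only one of these. As far as these compounds go, how a carboxylic acid in place of ethoxycarbonyl, or a longer chain carrying ((2-fluorophenoxy)carbonyl)amino, would read in this assay also remains open.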